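This account rests on a few compounds, and the source may have more. Where it says the series, first, only, none or still open, it means among the compounds named here.

Measured compounds in a physicochemical assay for lipophilicity, in phosphate buffer, measured as octanol-water partition, at pH 7.4; a lower number here means a more polar compound, a higher number a more lipophilic compound:

compound 1, `CCC(C)CN(C)/N=N/c1ccc(C(=O)O)cc1`: 1.33
compound 2, `C=CCN(C)/N=N/c1ccc(C(=O)O)cc1`: 0.32
compound 3, `CCCCCCCN(C)/N=N/c1ccc(C(=O)O)cc1`: 2.58

Compound 1 sits second highest of the three numbers in this assay. Its nearest neighbour is compound 2, reached by a number 1.01 log units lower from compound 1 to compound 2 (beyond the scatter), and its furthest is compound 3, reached by a number 1.25 log units higher from compound 1 to compound 3 (beyond the scatter); between compounds 2 and 3 the step is a number 2.26 log units higher from compound 2 to compound 3 (beyond the scatter). All three steps are beyond the scatter and all concern the length of the chain on the saturated chain carbon bound to the amine nitrogen.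

The unmeasured compound 4, `CCCCCN(C)/N=N/c1ccc(C(=O)O)cc1`, differs from compound 1 by butyl in place of sec-butyl on a saturated chain carbon bound to an amine nitrogen. For the measured compounds named here, this is a rearrangement of the same atoms, not a change in chain length, so none of the measured steps bears on it directly; the chain-length steps only bracket the region in which compound 4 should fall. With no added or removed carbon, the step in this assay from compound 1 to compound 4 is expected to be small, at most a slight rise, and likely within the scatter: the expected step is a number 0.12 log units higher from compound 1 to compound 4 (within the scatter). Compound 4 is therefore estimated at 1.45, within a range of 1.1 to 1.8.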

Compound 4, distribution coefficient: 1.49
Estimate against measurement, compound 4: 0.04 log units below; the measured number falls inside the stated range.
By their numbers in this assay, from the lowest: compound 2; then compounds 1 and 4 (each within the scatter of the next); then compound 3.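

In this assay, for the compounds shown here, butyl in place of sec-butyl on a saturated chain carbon bound to an amine nitrogen gives a number 0.16 log units higher from compound 1 to compound 4 (within the scatter), the first step that keeps the same atoms and changes only how they are joined; read one bond further out, this is pentyl in place of 2-methylbutyl. By contrast, hydrogen in place of ethyl on a saturated chain carbon, five bonds along the chain from an amine nitrogen, gives a number 1.09 log units lower from compound 3 to compound 4 (beyond the scatter), and swapping vinyl for butyl gives a number 1.17 log units higher from compound 2 to compound 4 (beyond the scatter), so among these four compounds the one step within the scatter is the one that leaves the atoms unchanged, and no compound goes against this. No measurement at hand accounts for any of these steps.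

A single branched and straight pair cannot show whether the same holds for a more heavily branched group such as tert-butyl or for a ring such as cyclopentyl at this position. Also open, from the compounds shown here alone, is how a terminal amine, a hydroxyl or a carboxylic acid on the chain would sit against the plain carbon chains in this assay, since every chain here carries carbon alone.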